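Working notes on an epimeric step at a ring stereocentre

This account rests on a few compounds, and the source may have more. Where it says the series, first, only, none or still open, it means among the compounds named here.

The set comprises compound 1 `CC(C)=C1CC[C@]2(C)CC[C@]3(O[C@H](C[C@@H]3C)C[C@]3(C)O[C@H]3C1=O)O2`, compound 2 `CC(=O)O[C@@]1(C)CCC(=O)[C@@H](C)CCC[C@]2(C)O[C@H]2C(=O)C(=C(C)C)CC1` and compound 3 `CC(=O)O[C@]1(C)CCC(=C(C)C)C(=O)[C@@H]2O[C@@]2(C)C[C@H]2C[C@H](C)[C@@](O)(CC1)O2`, all tested in a functional assay on A549 cells (Homo sapiens) for cytotoxicity, read by MTT assay, with a stated time of 24 h; on this read-out higher numbers stand for weaker inhibition and lower numbers for stronger inhibition. For compound 1 only a limit is recorded: in this assay compound 1 gives > 50000 nM, a limit of the assay and not a number. Within the data shown here, compound 2 is the one member with a number, giving 31100 nM in this assay. For compound 3 the read-out is again a limit: compound 3 gives > 50000 nM. Compound 1 therefore stands at the limit of > 50000 nM in this assay, at which 2 of the 3 values shown sit; it cannot be ranked against compound 3, and against compound 2 the limit permits no ordering. No two of these measured compounds differ in a single place, so no step size is available from the measured set.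

Compound 4 `CC(C)=C1CC[C@]2(C)CC[C@]3(O[C@H](C[C@H]3C)C[C@]3(C)O[C@H]3C1=O)O2` is the next candidate. Its relation to compound 1: the two compounds have the same atoms and bonds and differ only in configuration as drawn: 1 of 6 stereo elements differ; a stereocentre at a saturated ring carbon is drawn S in compound 1 and R in compound 4. Among the measured compounds shown here, no measured pair informs on such an inversion here. With compound 1 at a limit and the alteration confined to one stereocentre, no step beyond the scatter is assumed; the expected step that the limit leaves unreadable from compound 1 to compound 4 is accordingly flat. Compound 4 is estimated at 60000 nM, within 30000 nM to 150000 nM, most probably reported once more as a limit.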

Compound 4, half-maximal inhibitory concentration: > 50000 nM
Compound 4: no number, only a limit; the forecaster's own chance of this, stated with the estimate: 80%; the middle value lies beyond the limit too.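

Among these compounds, compound 1 and compound 4 are both recorded only as limits, so no step between them can be read: the limit of > 50000 nM in this assay, at which 3 of the 4 values shown sit. The compounds shown leave open whether inverting the stereocentre at the saturated ring carbon changes the cytotoxicity read-out at all, and any difference between compound 1 and compound 4 remains hidden behind that limit.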